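Swapping the benzyl halide pattern on a piperidine amine

The compounds below may be only part of what the source reports. "The series", "measured", "known", "first", "only" and "open" are said of these compounds alone.

Within the data shown here, compound 1 `O=c1c2cnn(-c3ccc(F)cc3)c2ncn1CC1(O)CCN(Cc2ccccc2Br)CC1` is the only compound here with a number: in an assay on Sf21 cells for inhibition of ubiquitin carboxyl-terminal hydrolase 7 (Homo sapiens), read by spectrophotometry, with stated times of 30 min and 2 h (a lower number here means a stronger inhibitor, a higher number a weaker inhibitor), compound 1 gives 3100 nM. Compound 2 `COC(=O)c1cccc(CN2CCC(O)(Cn3cnc4c(cnn4-c4ccc(F)cc4)c3=O)CC2)c1` shares the core, but in this assay compound 2 has "not determined" (no result reported). Compound 3 `O=c1c2cnn(-c3ccc(F)cc3)c2ncn1CC1(O)CCN(Cc2ccc(Br)cc2Cl)CC1` differs from compound 1 by 4-bromo-2-chlorophenyl in place of 2-bromophenyl on a saturated chain carbon bound to an amine nitrogen in a ring. Among the measured compounds shown here, no step between measured compounds guides this change, so the account expects only a small shift in this assay, most likely within the scatter, in either direction. Compound 3 is therefore estimated at 2500 nM, in a range from 800 nM to 8000 nM. That estimate means an expected step of a 1.2-fold lower number from compound 1 to compound 3 (0.09 log units; within the scatter).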

Compound 3, half-maximal inhibitory concentration: 1900 nM
Compound 3: the middle estimate sits 1.3-fold (0.12 log units) above what was measured, within the range that was stated.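

In this assay, 4-bromo-2-chlorophenyl in place of 2-bromophenyl gives a 1.6-fold lower number from compound 1 to compound 3 (0.21 log units; within the scatter), so compound 1 and compound 3 cannot be told apart at this position, on a saturated chain carbon bound to an amine nitrogen in a ring. At this place, then, the two halogen patterns read alike. Nothing measured here accounts for this result. On these data alone, whether a carboxylic acid or an amine in place of these halogens would move the number beyond the scatter remains open.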